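Fluoro on the pendant phenyl of a piperidine-tailed amide

A few compounds are considered here, and "the series" means these few. Any claim that something is new, unique, unknown or untested is made for them only; others in the source may bear on it.

Measured compounds:
compound 1 `COc1cc2c(Oc3ccc(NC(=O)c4nn(-c5ccccc5F)c(=O)c5ccccc45)cc3F)ccnc2cc1OCCCN1CCN(C)CC1` 230 nM
compound 2 `COc1cc2c(Oc3ccc(NC(=O)c4nn(-c5ccccc5)c(=O)c5ccccc45)cc3F)ccnc2cc1OCCCN1CCCCC1` 650 nM

In a functional assay on NCI-H460 cells (Homo sapiens) for cytotoxicity, read by MTT assay, with a stated time of 72 h (a lower number here means a stronger inhibitor, a higher number a weaker inhibitor), compound 2 gives the higher of the two numbers shown, while compound 1 gives 230 nM, a gap beyond the scatter; the two differ in more than one place, so their values alone are what can be said. Compound 3 `COc1cc2c(Oc3ccc(NC(=O)c4nn(-c5ccccc5F)c(=O)c5ccccc45)cc3F)ccnc2cc1OCCCN1CCCCC1` differs from compound 2 by fluoro in place of hydrogen on an aromatic carbon, a fluoro in place of hydrogen on an aromatic carbon, ortho to a large group. Among the measured compounds shown here, no single-change step has been measured for this, so a small step in the direction of lower numbers is expected, given that compound 1 carries the same 2-fluorophenyl and gives 230 nM. For compound 3 the expected step is a 1.6-fold lower number from compound 2 to compound 3 (0.21 log units; within the scatter). Compound 3 is estimated at 400 nM, within 150 nM to 1100 nM.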

Compound 3, half-maximal inhibitory concentration: 160 nM
The estimate for compound 3 lay 2.5-fold (0.40 log units) above the measured number, within the range that was stated.
By their numbers in this assay, from the lowest: compounds 3 and 1 (each within the scatter of the next); then compound 2.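

In this assay, among the compounds shown here, the change from phenyl to 2-fluorophenyl gives a 4.1-fold lower number from compound 2 to compound 3 (0.61 log units; beyond the scatter) and so provides the first single-change reading at this position, with a step beyond the scatter. Exchanging 4-methylpiperazin-1-yl for piperidin-1-yl on the chain, with the 2-fluorophenyl kept, gives a 1.4-fold lower number from compound 1 to compound 3 (0.16 log units; within the scatter) and does not separate these two tails. Nothing available explains the step seen with fluoro. As far as these compounds go, it remains open whether a chloro or methyl group on that aromatic carbon would give a similar step, and how large the fluoro step would be with the 4-methylpiperazin-1-yl tail.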